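The source may report more compounds than this note shows. Statements on the series, on what has been measured and on what is new or still open speak of the compounds shown alone.

In an assay for binding affinity to Amine oxidase [flavin-containing] A (Homo sapiens) (on this read-out lower numbers stand for stronger inhibition and higher numbers for weaker inhibition), compound 1 `O=Cc1cn(C[C@H]2CN(c3ccc(C4=CCS(=O)(=O)CC4)c(F)c3)C(=O)O2)nn1` gives 3200 nM. Compound 2 `C[Si](C)(C)C#Cc1cn(C[C@H]2CN(c3ccc(C4=CCS(=O)(=O)CC4)c(F)c3)C(=O)O2)nn1` is recorded in this assay only as a limit, > 200000 nM, so its true number is not known. For the measured compounds named here, the one measured step, an at least 62-fold higher number from compound 1 to compound 2 (1.79 log units; beyond the scatter), therefore tells only a bound on the change because the limit of > 200000 nM in this assay, at which 1 of the 2 values shown sits, caps the second value rather than fixing it. Compound 3 `O=C1O[C@@H](Cn2cc(CO)nn2)CN1c1ccc(C2=CCS(=O)(=O)CC2)c(F)c1` has not yet been measured in this assay. It differs from compound 2 by a group of 2 heavy atoms (1 carbon, 1 oxygen; no ring) in place of a group of 6 heavy atoms (5 carbon, 1 silicon; no ring), on an aromatic carbon. This largely undoes the earlier change: the bulky silicon-containing group that replaced the aldehyde of compound 1 is swapped back for a small oxygen-bearing group, and hydroxymethyl and aldehyde resemble each other in size. The step from compound 1 to compound 2 was large and in the weakening direction, so a large step in the strengthening direction is expected here, though the aldehyde and hydroxymethyl groups are not identical and some loss against compound 1 is allowed for. Compound 3 is therefore estimated at 10000 nM in this assay, with a range from 2000 nM to 60000 nM. The expected step is an at least 20-fold lower number from compound 2 to compound 3 (1.30 log units; beyond the scatter).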

Compound 3, inhibition constant: 47000 nM
Compound 3: middle estimate off by 4.7-fold (0.67 log units), on the low side; the measured number falls inside the stated range.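

In this assay, this position on the five-membered aromatic ring with 3 nitrogen now gives its first step with a true number at both ends: hydroxymethyl in place of formyl produces a 15-fold higher number from compound 1 to compound 3 (1.17 log units; beyond the scatter). So the two small groups are not interchangeable here, and a small group alone does not bring back the number of compound 1. Going the other way, putting hydroxymethyl in place of the silicon-containing group gives an at least 4.2-fold lower number from compound 2 to compound 3 (0.62 log units; beyond the scatter), which is a bound rather than a measured size, because compound 2 is recorded only at a limit: the limit of > 200000 nM in this assay, at which 1 of the 3 values shown sits.

On these data alone, the true cost of the silicon-containing group therefore stays unknown, and so does how much of the distance back to compound 1 the hydroxymethyl group recovers. The compounds shown also leave open whether a different small group at this position, such as an amine, a carboxylic acid or a plain methyl, would give a number lower than that of compound 1 or one closer to that of compound 3.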